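A few compounds are considered here, and "the series" means these few. Any claim that something is new, unique, unknown or untested is made for them only; others in the source may bear on it.

In a functional assay on MCF7 cells (Homo sapiens) for antiproliferative activity, read by sulforhodamine B assay, with a stated time of 48 h (on this read-out higher numbers stand for weaker inhibition of growth and lower numbers for stronger inhibition of growth), compound 1, `COc1ccc(Cn2cc(CNC(=O)c3cn(-c4ccccc4)nc3-c3ccc(F)cc3)nn2)cc1OC`, returns only a limit of the assay, > 100000 nM. Compound 2, `COc1cc(Cn2cc(CNC(=O)c3cn(-c4ccccc4)nc3-c3ccc(F)cc3)nn2)cc(OC)c1`, differs from compound 1 by 3,5-dimethoxyphenyl in place of 3,4-dimethoxyphenyl on a saturated chain carbon bound to an aromatic nitrogen. In this assay compound 2 gives 2500 nM. That single change produced an at least 40-fold lower number from compound 1 to compound 2 (1.60 log units; beyond the scatter). Compound 3, `COc1ccc(Cn2cc(CNC(=O)c3cn(-c4ccccc4)nc3-c3ccc(Cl)cc3)nn2)cc1OC`, differs from compound 1 by chloro in place of fluoro on an aromatic carbon. Compound 3 likewise returns only a limit of the assay, > 100000 nM. Since compound 1 and compound 3 both sit at the limit of > 100000 nM in this assay, at which 2 of the 3 values shown sit, the comparison shows a step that the two limits leave unreadable from compound 1 to compound 3. Compound 4, `COc1cc(Cn2cc(CNC(=O)c3cn(-c4ccccc4)nc3-c3ccc(Cl)cc3)nn2)cc(OC)c1`, is not yet measured; it differs from compound 3 by 3,5-dimethoxyphenyl in place of 3,4-dimethoxyphenyl on a saturated chain carbon bound to an aromatic nitrogen, which is the same change, at the same place, that separates compound 1 from compound 2. Because that change gave an at least 40-fold lower number from compound 1 to compound 2 (1.60 log units; beyond the scatter), a step of comparable size is expected here, namely an at least 33-fold lower number from compound 3 to compound 4 (1.52 log units; beyond the scatter), though with a starting point that is itself only a limit the size cannot be pinned down closely. On that basis compound 4 is expected to give 3000 nM, with a likely range from 700 nM to 15000 nM.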

Compound 4, concentration for 50% growth inhibition: 150 nM
Estimate against measurement, compound 4: 20-fold (1.30 log units) above; the whole stated range lies above it.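

In this assay, the swap of 3,4-dimethoxyphenyl for 3,5-dimethoxyphenyl kept its direction when carried from the fluoro compounds to the chloro compounds, giving an at least 660-fold lower number from compound 3 to compound 4 (2.82 log units; beyond the scatter). Set beside the earlier case, the result reads: the same change on two cores in this assay, an at least 40-fold lower number (1.60 log units; beyond the scatter) from compound 1 to compound 2 and an at least 660-fold lower number (2.82 log units; beyond the scatter) from compound 3 to compound 4; the limit leaves it open whether they differ. So the direction held in both pairs shown, but these two pairs cannot establish a general rule, and the size of the step cannot be compared, since compound 1 and compound 3 both give only a limit: the limit of > 100000 nM in this assay, at which 2 of the 4 values shown sit.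

Chloro in place of fluoro gave a 17-fold lower number from compound 2 to compound 4 (1.22 log units; beyond the scatter), whereas the matching step between the two 3,4-dimethoxyphenyl compounds cannot be read, so it remains open whether this swap depends on the methoxy pattern. Also open, as far as these compounds go, is how a phenyl carrying a single methoxy group, or a bromo in place of the chloro, would behave in this assay.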